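The source may hold more compounds than are shown below. What is called first, only, known or untested is meant among the compounds shown, and "the series" means these compounds.

Among the compounds with values here, in a functional assay on A549 cells (Homo sapiens) for antiproliferative activity, read by MTT assay, with a stated time of 48 h (a lower number here means a stronger inhibitor, a higher number a weaker inhibitor), compound 3 `C=C(/C(C)=C/c1ccc(OC)c(O)c1)c1cc(OC)c(OC)c(OC)c1` gives 56 nM, the lowest number among the three compounds measured so far. On the same read-out, compound 1 `CC=C(/C=C/c1ccc(OC)c(N)c1)c1cc(OC)c(OC)c(OC)c1` gives 247 nM, and compound 2 `CCC=C(/C=C/c1ccc(OC)c(N)c1)c1cc(OC)c(OC)c(OC)c1` gives 398 nM. Compound 4 `CC=C(/C(C)=C/c1ccc(OC)c(O)c1)c1cc(OC)c(OC)c(OC)c1` has not yet been measured. It differs from compound 3 by a single change: methyl in place of hydrogen on a double-bonded chain carbon bound to a double-bonded chain carbon, which places methyl in place of hydrogen on a double-bonded chain carbon bound to a double-bonded chain carbon. Within the data shown here, the only measured step of a similar kind is a 1.6-fold higher number from compound 1 to compound 2 (0.21 log units; within the scatter), where methyl replaces hydrogen on a saturated chain carbon bound to a double-bonded chain carbon. That step stayed within the scatter. It is only a rough guide, though, since the carbon is a different one and compounds 1 and 2 also differ from compound 3 elsewhere in the structure. A similarly small rise, not clearly beyond the scatter, is therefore expected, and the estimated step is a 1.5-fold higher number from compound 3 to compound 4 (0.18 log units; within the scatter). Compound 4 is expected to give about 85 nM, with an estimated range from 30 nM to 240 nM.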

Compound 4, half-maximal inhibitory concentration: 637 nM
Compound 4: middle estimate off by 7.5-fold (0.87 log units), on the low side; measured number outside the range, above it.
By their numbers in this assay, from the lowest: compound 3; then compounds 1, 2 and 4 (each within the scatter of the next, the first and the last beyond it).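

In this assay, a single methyl on a double-bonded chain carbon bound to a double-bonded chain carbon gives a large change: an 11-fold higher number from compound 3 to compound 4 (1.06 log units; beyond the scatter) is beyond the scatter. The earlier methyl step, a 1.6-fold higher number from compound 1 to compound 2 (0.21 log units; within the scatter) on a saturated chain carbon, stayed within the scatter, which shows that one added carbon does not have the same size of effect at every place in the chain, although the two pairs also differ elsewhere in their structures. Nothing available gives a measured reason for the size of this step.

The compounds shown leave open whether a chlorine atom or a longer chain such as propyl on this same carbon would bring a similar rise in the number. They also leave open whether the methyl would produce a step of this size in compounds that carry the amine of compound 1.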